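Substituent Swap at One Aromatic Position: Expected Outcome

The source may hold more compounds than are shown below. What is called first, only, known or untested is meant among the compounds shown, and "the series" means these compounds.

Measured in a functional assay on AGS cells (Homo sapiens) for antiproliferative activity, read by CCK-8 assay, with a stated time of 72 h; on this read-out higher numbers stand for weaker inhibition and lower numbers for stronger inhibition:
Compound 1 `COc1ccn2c(-c3ccc(NC(=O)c4ccc([N+](=O)[O-])o4)cc3)cnc2c1`: 720 nM
Compound 2 `COc1ccn2c(-c3ccc(NC(=O)c4ccc([N+](=O)[O-])o4)cc3F)cnc2c1`: 700 nM
Compound 3 `COc1ccn2c(-c3ccc(NC(=O)c4ccc([N+](=O)[O-])o4)cc3C)cnc2c1`: 640 nM

Compound 3 sits together with the other two, since the differences a 1.1-fold lower number from compound 1 to compound 3 (0.05 log units; within the scatter) and a 1.1-fold lower number from compound 2 to compound 3 (0.04 log units; within the scatter) both fall inside the scatter. Compound 4 `COc1ccn2c(-c3ccc(NC(=O)c4ccc([N+](=O)[O-])o4)cc3OC)cnc2c1` differs from compound 3 by methoxy in place of methyl on an aromatic carbon. The three measured steps at this same position, a 1.0-fold lower number from compound 1 to compound 2 (0.01 log units; within the scatter), a 1.1-fold lower number from compound 1 to compound 3 (0.05 log units; within the scatter) and a 1.1-fold lower number from compound 2 to compound 3 (0.04 log units; within the scatter), were all small, so a further swap there is expected to leave this assay unchanged beyond the scatter. The expected step is no change at the digits printed from compound 3 to compound 4 (within the scatter). Compound 4 is therefore estimated at 640 nM, with a range from 350 nM to 1200 nM.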

Compound 4, half-maximal inhibitory concentration: > 20000 nM
Compound 4 was reported as a limit; the forecaster's own chance of this, stated with the estimate: 2%; middle value at least 31-fold (1.49 log units) from the limit.
By their numbers in this assay, from the lowest: compounds 3, 2 and 1 (each within the scatter of the next). At a limit, above all of these: compound 4.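

The position is less forgiving than hydrogen, fluoro and methyl suggested: in this assay, methoxy gives an at least 31-fold higher number from compound 3 to compound 4 (1.49 log units; beyond the scatter), and the other two steps are just as large, an at least 28-fold higher number from compound 2 to compound 4 (1.45 log units; beyond the scatter) and an at least 27-fold higher number from compound 1 to compound 4 (1.44 log units; beyond the scatter). A small change is enough, since methoxy has 2 heavy atoms and 1 hydrogen-bond acceptor, against 1 heavy atom and 0 acceptors for methyl. The reading for compound 4 is a limit, not a number: the limit of > 20000 nM in this assay, at which 1 of the 4 values shown sits.

Whether the oxygen or the larger size accounts for the step remains open. A hydroxyl or an ethyl group at this position would help separate the two.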